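The source may report more compounds than this note shows. Statements on the series, on what has been measured and on what is new or still open speak of the compounds shown alone.

Measured in an ADME assay on CHO-K1 cells (Cricetulus griseus) for cytotoxicity, read by MTT assay, with a stated time of 24 h; on this read-out higher numbers stand for lower toxicity in this test and lower numbers for higher toxicity in this test:
- compound 1 `S=C(Nc1ccccc1)Nc1ccc2[nH]ccc2c1`: 337000 nM
- compound 2 `Oc1ccc(NC(=S)Nc2ccc3[nH]ccc3c2)cc1`: 848000 nM
- compound 3 `COc1ccc(NC(=S)Nc2ccc3[nH]ccc3c2)cc1`: 476000 nM

Numerically, compound 3 is the middle of the three, but it lies within the scatter of both others. The two steps that reach it are a 1.4-fold higher number from compound 1 to compound 3 (0.15 log units; within the scatter) and a 1.8-fold lower number from compound 2 to compound 3 (0.25 log units; within the scatter). Only a 2.5-fold higher number from compound 1 to compound 2 (0.40 log units; beyond the scatter) goes beyond the scatter, and it is modest.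

The next compound is compound 4 `S=C(Nc1ccc(Oc2ccccc2)cc1)Nc1ccc2[nH]ccc2c1`. It differs from compound 3 as follows: phenyl in place of methyl on an oxygen on an aromatic ring. In words, this is phenyl in place of methyl on an oxygen on an aromatic ring, or methoxy to phenoxy.

The closest measured change is the one on that same oxygen, methyl in place of hydrogen, which gave a 1.8-fold lower number from compound 2 to compound 3 (0.25 log units; within the scatter). The step from hydrogen to methoxy on the aromatic carbon, a 1.4-fold higher number from compound 1 to compound 3 (0.15 log units; within the scatter), is also small. Among the measured compounds shown here, no measured compound carries a phenyl on that oxygen, so the direction is poorly supported. A large step in this assay is therefore not expected, only a slight lean towards a lower number, probably not beyond the scatter.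

The expected step is a 1.6-fold lower number from compound 3 to compound 4 (0.20 log units; within the scatter).

For compound 4 the estimated value is 300000 nM, with an expected range from 120000 nM to 700000 nM.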

Compound 4, concentration lethal to 50% of the cells: 36000 nM
For compound 4 the middle estimate is 8.3-fold (0.92 log units) above the measured one; measured number outside the range, below it.
By their numbers in this assay, from the lowest: compound 4; then compounds 1, 3 and 2 (each within the scatter of the next, the first and the last beyond it).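

In this assay the oxygen on the aromatic ring turned out to be far from indifferent to what it carries: methyl in place of hydrogen there gave only a 1.8-fold lower number from compound 2 to compound 3 (0.25 log units; within the scatter) and stayed within the scatter, whereas phenyl gave a 13-fold lower number from compound 3 to compound 4 (1.12 log units; beyond the scatter) and, measured against the hydroxy compound, a 24-fold lower number from compound 2 to compound 4 (1.37 log units; beyond the scatter) as large steps. Against the unsubstituted ring, phenoxy in place of hydrogen on the aromatic carbon gave a 9.4-fold lower number from compound 1 to compound 4 (0.97 log units; beyond the scatter) as a modest step, so compound 4 alone stands apart from the other three, with the highest toxicity in this test, while the earlier compounds had spanned little more than the scatter. Nothing shown here gives a measured reason for this drop, so the result stands as an observation about the phenyl group without an explanation.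

The compounds shown leave open whether any larger group on that oxygen would have a similar effect or whether it takes an aromatic ring, which a longer chain such as butyl, or a benzyl group, would help to separate. They also leave open how a substituent on the new phenyl ring, such as a carboxylic acid or an amine, would shift the number in this assay for a compound of this kind.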